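Swapping the amine ring on a weak cytotoxic series

The source may report more compounds than this note shows. Statements on the series, on what has been measured and on what is new or still open speak of the compounds shown alone.

Of the compounds shown here, three built on a shared core have been measured in a functional assay on DLD-1 cells (Homo sapiens) for cytotoxicity, read by WST assay, with a stated time of 72 h; a lower number here means a stronger inhibitor, a higher number a weaker inhibitor. Compound 1 `COc1cc2c(Nc3nc4ccc(C(=O)Nc5c(C)cc(C)cc5C)cc4s3)ncnc2cc1OCCCN1CCC(C)CC1` gives 7000 nM. Compound 2 `COc1cc2c(Nc3nc4ccc(C(=O)Nc5c(C)cccc5C)cc4s3)ncnc2cc1OCCCN1CCC(C)CC1` reaches only the limit of this assay, > 100000 nM, so no number is known for it. Compound 3 `COc1cc2c(Nc3nc4ccc(C(=O)Nc5c(C)cccc5Cl)cc4s3)ncnc2cc1OCCCN1CCCC1` gives 60700 nM, which is the highest of the two numbers seen, with compound 1 as its nearest neighbour.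

Among the compounds with values here, the one measured step between compounds differing in a single place, an at least 14-fold higher number from compound 1 to compound 2 (1.15 log units; beyond the scatter), concerns the aromatic ring that carries the amide and runs up to the limit of > 100000 nM in this assay, at which 1 of the 3 values shown sits. Compound 4 `COc1cc2c(Nc3nc4ccc(C(=O)Nc5c(C)cccc5Cl)cc4s3)ncnc2cc1OCCCN1CCC(C)CC1` instead changes the amine at the end of the chain: 4-methylpiperidin-1-yl in place of pyrrolidin-1-yl on a saturated chain carbon, three bonds along the chain from an oxygen on an aromatic ring. Within the data shown here, no measured step touches this part of the molecule, so there is nothing to say how much the number should move, and the expectation is for a change that stays within the usual scatter of this assay, with no clear direction.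

Compound 4 is therefore expected to give about 45000 nM, between 12000 nM and 150000 nM; this estimate amounts to a 1.3-fold lower number from compound 3 to compound 4 (0.13 log units; within the scatter), a step too small to count as a real change.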

Compound 4, half-maximal inhibitory concentration: 11300 nM
For compound 4 the middle estimate is 4.0-fold (0.60 log units) above the measured one, outside the stated range (below it).
By their numbers in this assay, from the lowest: compounds 1 and 4 (each within the scatter of the next); then compound 3. At a limit, above all of these: compound 2.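

In this assay, within the data shown here, the amine at the end of the chain proves to matter, with a 5.4-fold lower number from compound 3 to compound 4 (0.73 log units; beyond the scatter), the first measured step at this part of the molecule. With 4-methylpiperidin-1-yl held fixed, chloro in place of methyl on the aromatic ring of the amide gives an at least 8.8-fold lower number from compound 2 to compound 4 (0.94 log units; beyond the scatter), a step that rests on a limit and not on a number at one end: the limit of > 100000 nM in this assay, at which 1 of the 4 values shown sits. The other change on that ring, 2-chloro-6-methylphenyl in place of 2,4,6-trimethylphenyl, gives a 1.6-fold higher number from compound 1 to compound 4 (0.21 log units; within the scatter), so these two amide groups cannot be told apart here, and both sit far from the limit when paired with this amine.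

Among these compounds, the amine step has been seen with only one amide group, 2-chloro-6-methylphenyl, so whether it carries over to 2,4,6-trimethylphenyl remains an open question. A plain piperidin-1-yl would show whether the larger ring or the methyl on it goes with the lower number, and morpholin-4-yl or a longer chain would show how far this part of the molecule can be changed.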